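Notes on the amine nitrogen substituent of compound 2

The compounds below may be only part of what the source reports. "The series", "measured", "known", "first", "only" and "open" are said of these compounds alone.

Measured compounds:
compound 1 `O=S(=O)(c1cccc(F)c1)c1ccc2c(c1)CCC[C@H]2CN1CCCS1(=O)=O` — 31.6 nM
compound 2 `O=C(NC[C@@H]1CCCc2cc(S(=O)(=O)c3cccc(F)c3)ccc21)c1ccc[nH]1` — 5.01 nM

Within the data shown here, in an assay on isolated protein for displacement of a labelled ligand from 5-hydroxytryptamine receptor 6 (Homo sapiens) (on this read-out higher numbers stand for weaker inhibition and lower numbers for stronger inhibition), compound 2 gives the lowest of the two numbers; the only comparison is a 6.3-fold lower number from compound 1 to compound 2 (0.80 log units; beyond the scatter). Compound 3 `NC(=O)CNC[C@@H]1CCCc2cc(S(=O)(=O)c3cccc(F)c3)ccc21` differs from compound 2 by carbamoylmethyl in place of (1H-pyrrol-2-yl)carbonyl on an amine nitrogen. The measured step of a 6.3-fold lower number from compound 1 to compound 2 (0.80 log units; beyond the scatter) bears on this, since it also changed the group at the amine nitrogen, and the group with one five-membered aromatic ring gave the lower number. Compound 3 carries no ring there, so a rise in this assay of about a 10-fold higher number from compound 2 to compound 3 (1.00 log units; beyond the scatter) is expected. Compound 3 is estimated at 50 nM, with a range of 10 nM to 250 nM.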

Compound 3, inhibition constant: 0.1 nM
Compound 3: middle estimate off by 500-fold (2.70 log units), on the high side, and the stated range ends above it.
By their numbers in this assay, from the lowest: compound 3; then compound 2; then compound 1.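

In this assay this position tolerates far more than the earlier pair showed, and no aromatic ring is needed on the amine nitrogen: carbamoylmethyl, which has no ring, gives a 50-fold lower number from compound 2 to compound 3 (1.70 log units; beyond the scatter) in place of (1H-pyrrol-2-yl)carbonyl. Across the wider change the step is a 320-fold lower number from compound 1 to compound 3 (2.50 log units; beyond the scatter) and exceeds the earlier 6.3-fold lower number from compound 1 to compound 2 (0.80 log units; beyond the scatter) on the same substituent site. No supporting measurement is available to account for the size of these steps.

Going by these compounds, it remains open whether the gain follows the terminal amide of carbamoylmethyl or the loss of the carbonyl directly on the amine nitrogen. A plain ethyl group, a carboxylic acid or a longer chain ending in the same amide would help separate these.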